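The source may report more compounds than this note shows. Statements on the series, on what has been measured and on what is new or still open speak of the compounds shown alone.

Three compounds share one core. Compound 1 `COC(=O)C1=C(C)N=C(C)/C(=C(\O)OC)C1c1ccccc1C#N` carries a 2-cyanophenyl group and gives 15.9 nM in a functional assay (muscle tissue) with Cavia porcellus as the target (on this read-out higher numbers stand for an effect only at larger amounts of compound and lower numbers for an effect already at smaller amounts), the lowest of the three numbers. Compound 2 `COC(=O)C1=C(C)N=C(C)/C(=C(\O)OC)C1c1cc([N+](=O)[O-])ccc1Cl` gives 30.2 nM, within the scatter of compound 1. Among the compounds with values here, compound 3 `CCOc1ccccc1C1C(C(=O)OC)=C(C)N=C(C)/C1=C(\O)OC` gives 110 nM; the change a 6.9-fold higher number from compound 1 to compound 3 (0.84 log units; beyond the scatter) is the only measured step, and it concerns a different alteration of the same phenyl group. Compound 4 `COC(=O)C1=C(C)N=C(C)/C(=C(\O)OC)C1c1ccc(Br)cc1` differs from compound 1 by 4-bromophenyl in place of 2-cyanophenyl on a saturated ring carbon. Within the data shown here, no measured step matches this change, so the expectation rests loosely on the step from compound 1 to compound 3, where altering the phenyl group weakened the effect. Compound 4 is therefore expected to give 150 nM, between 40 nM and 600 nM, an estimated step of a 9.4-fold higher number from compound 1 to compound 4 (0.97 log units; beyond the scatter).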

Compound 4, half-maximal effective concentration: 540 nM
For compound 4 the middle estimate is 3.6-fold (0.56 log units) below the measured one, within the range that was stated.
By their numbers in this assay, from the lowest: compounds 1 and 2 (each within the scatter of the next); then compound 3; then compound 4.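

In this assay the swap on the saturated ring carbon gives a 34-fold higher number from compound 1 to compound 4 (1.53 log units; beyond the scatter) and so exceeds the earlier step of a 6.9-fold higher number from compound 1 to compound 3 (0.84 log units; beyond the scatter). Within the data shown here, the group on this carbon can therefore move the number further than the earlier compounds showed, even though both groups are phenyl rings with one substituent. Nothing measured here explains the size of this step.

This single swap changes both the substituent and its place on the phenyl ring, so the two effects cannot be separated. As far as these compounds go, how an amine or a carboxylic acid on that ring would read also remains open.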